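Compound 3: replacing the 1-benzofuran-2-yl group

This account rests on a few compounds, and the source may have more. Where it says the series, first, only, none or still open, it means among the compounds named here.

Compound 1 `c1ccc(-c2ccc(Cn3cncc3CNc3ccc(-c4ccc[nH]4)c(-c4ccccc4)c3)cc2)cc1` gives > 10000 nM (a limit)
Compound 2 `c1ccc(-c2ccc(Cn3cncc3CNc3ccc(-c4cc5ccccc5o4)c(-c4ccccc4)c3)cc2)cc1` gives > 10000 nM (a limit)

In a toxicity assay on NIH3T3 cells (Mus musculus) for cytotoxicity, read by resazurin assay (on this read-out lower numbers stand for an effect already at smaller amounts and higher numbers for an effect only at larger amounts of compound), compound 2 gives > 10000 nM as a limit of the assay and not as a number. Compound 1 likewise gives only a limit, so the whole record so far is one point (the limit of > 10000 nM in this assay, at which 2 of the 2 values shown sit).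

Compound 3 `c1ccc(-c2ccc(Cn3cncc3CNc3ccc(-c4onc5ccccc45)c(-c4ccccc4)c3)cc2)cc1` differs from compound 2 at a single place, on an aromatic carbon of a six-membered aromatic ring of carbon only, ortho to a phenyl group and para to a large group (a group of 9 heavy atoms (7 carbon, 1 nitrogen, 1 oxygen; one five-membered aromatic ring with 2 hetero atoms, one six-membered aromatic ring of carbon only) in place of a group of 9 heavy atoms (8 carbon, 1 oxygen; one five-membered aromatic ring with 1 hetero atom, one six-membered aromatic ring of carbon only), on an aromatic carbon).

Among the compounds with values here, the one measured step at this place is a step that the two limits leave unreadable from compound 1 to compound 2 and it offers no size or direction to carry over. No step beyond the scatter is therefore expected in this assay. The expectation rests on compound 2 with its limit of > 10000 nM as the starting point. The expected change is a step that the limit leaves unreadable from compound 2 to compound 3 in the estimate. For compound 3 the estimated value is 20000 nM with an expected range from 7000 nM to 60000 nM and a report as a limit is the likeliest outcome.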

Compound 3, half-maximal effective concentration: > 10000 nM
Compound 3: no number, only a limit; the forecaster's own chance of this, stated with the estimate: 85%; the middle value lies beyond the limit too.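

In this assay compound 3 gives > 10000 nM, a limit of the assay and not a number. Compound 1 and compound 2 also give only limits, so no step among compound 1, compound 2 and compound 3 can be read: the limit of > 10000 nM in this assay, at which 3 of the 3 values shown sit.

The compounds shown leave open whether these three groups on the shared core differ at all in this assay.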